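An Amide in Place of the 3-Oxopiperazin-1-yl Group

This account rests on a few compounds, and the source may have more. Where it says the series, first, only, none or still open, it means among the compounds named here.

Of the compounds shown here, two sharing one core have been measured in an assay on isolated protein for displacement of a labelled ligand from 5-hydroxytryptamine receptor 6 (Homo sapiens); on this read-out higher numbers stand for weaker inhibition and lower numbers for stronger inhibition. Compound 1 `CC(=N)NCC1CCCc2cc(S(=O)(=O)c3ccccc3)ccc21` gives 0.631 nM in this assay. Compound 2 `O=C1CN(C[C@@H]2CCCc3cc(S(=O)(=O)c4cccc(F)c4)ccc32)CCN1` gives 6.31 nM in this assay, the higher of the two numbers, standing a full step above compound 1 and beyond the usual scatter. Compound 3 `CC(C)(C)C(=O)NC[C@@H]1CCCc2cc(S(=O)(=O)c3cccc(F)c3)ccc21` differs from compound 2 in a single place: ((tert-butyl)carbonyl)amino in place of 3-oxopiperazin-1-yl on a saturated chain carbon bound to a saturated ring carbon. A ring carrying two hetero atoms thus gives way to an open chain of the same heavy-atom count. Within the data shown here, no measured pair shows this exchange, so its effect is not known from the data at hand. The account expects compound 3 to bind more weakly than compound 2, with a step of a 6.3-fold higher number from compound 2 to compound 3 (0.80 log units; beyond the scatter) that lies beyond the scatter. Compound 3 is therefore estimated at 40 nM in this assay, within a range from 8 nM to 200 nM.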

Compound 3, inhibition constant: 3.98 nM
Estimate against measurement, compound 3: 10-fold (1.00 log units) above, and the stated range ends above it.
By their numbers in this assay, from the lowest: compound 1; then compounds 3 and 2 (each within the scatter of the next).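

In this assay, the exchange of 3-oxopiperazin-1-yl for ((tert-butyl)carbonyl)amino on a saturated chain carbon bound to a saturated ring carbon comes to a 1.6-fold lower number from compound 2 to compound 3 (0.20 log units; within the scatter), so the two groups cannot be told apart on this read-out. With the fluorine-bearing core held constant, this position thus accommodates an open chain as well as a six-membered non-aromatic ring with 2 hetero atoms, and neither the ring nor the second hydrogen-bond acceptor is shown to be required for binding in the low nanomolar range. No independent measurement is available to explain why the two groups read alike.

On these data alone, how a primary amine or an acetylamino group would read at this place remains open. Compound 1 differs from compound 2 and compound 3 in more than one place, so the contribution of the side chain of compound 1 to 0.631 nM also remains unresolved.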